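From a Fluoro to a Chloro Group on the Shared Core

The source may report more compounds than this note shows. Statements on the series, on what has been measured and on what is new or still open speak of the compounds shown alone.

Compound 2 `Nc1ncnn2c([C@@H]3O[C@H](CO)[C@@H](O)[C@H]3O)cc(-c3ccc(F)cc3)c12` carries a 4-fluorophenyl group on the shared core. In a functional assay on Z-138 cells (Homo sapiens) for antiproliferative activity, with a stated time of 72 h (a higher number here means a weaker inhibitor, a lower number a stronger inhibitor), compound 2 reaches only the limit > 100000 nM, so no number is known for it. Compound 1 `Nc1ncnn2c([C@@H]3O[C@H](CO)[C@@H](O)[C@H]3O)cc(C#Cc3ccccc3)c12` carries 2-phenylethynyl in that place and in this assay gives 41400 nM. The step of an at least 2.4-fold higher number from compound 1 to compound 2 (0.38 log units; beyond the scatter) rests on (the limit of > 100000 nM in this assay, at which 1 of the 2 values shown sits). Compound 3 `Nc1ncnn2c([C@@H]3O[C@H](CO)[C@@H](O)[C@H]3O)cc(-c3ccc(Cl)cc3)c12` differs from compound 2 by chloro in place of fluoro on an aromatic carbon. Going by the values given here, no measured step covers a change of this kind, so in this assay the expected step is a number no higher from compound 2 to compound 3 (the limit leaves the size open), none beyond the scatter. Compound 3 is therefore estimated at 100000 nM, between 40000 nM and 250000 nM.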

Compound 3, half-maximal inhibitory concentration: 40200 nM
The estimate for compound 3 lay 2.5-fold (0.40 log units) above the measured number, within the range that was stated.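

In this assay, chloro in place of fluoro on an aromatic carbon gives an at least 2.4-fold lower number from compound 2 to compound 3 (0.39 log units; beyond the scatter), so changing this single atom is enough to turn a limit into a measured number. That step starts from a limit for compound 2, not from a number: the limit of > 100000 nM in this assay, at which 1 of the 3 values shown sits. 4-Chlorophenyl in place of 2-phenylethynyl gives a 1.0-fold lower number from compound 1 to compound 3 (0.01 log units; within the scatter), so these two quite different groups cannot be told apart here.

From the compounds shown here alone, whether bromo, methyl or methoxy in this place would give a lower number remains open. So does the true size of the step from compound 2 to compound 3.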